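Extending the Amine Chain from Butyl to Octyl

This account rests on a few compounds, and the source may have more. Where it says the series, first, only, none or still open, it means among the compounds named here.

In a functional assay on NCI-H460 cells (Homo sapiens) for cytotoxicity, read by MTT assay, with a stated time of 72 h (on this read-out higher numbers stand for weaker inhibition and lower numbers for stronger inhibition), compound 1 `CCNC1=CC(=O)C(C(C)(C)C)=CC1=O` gives 65000 nM and compound 2 `CCCCNC1=CC(=O)C(C(C)(C)C)=CC1=O` gives 72000 nM. Among the compounds with values here, compound 2 thus stands level with compound 1 within the scatter, the one measured step being a 1.1-fold higher number from compound 1 to compound 2 (0.04 log units; within the scatter). Compound 3 `CCCCCCCCNC1=CC(=O)C(C(C)(C)C)=CC1=O` differs from compound 2 by butyl in place of hydrogen on a saturated chain carbon, four bonds along the chain from an amine nitrogen. Only that earlier chain extension bears on this change, so no shift beyond the scatter is expected in this assay. The expected step is a 1.3-fold lower number from compound 2 to compound 3 (0.12 log units; within the scatter). Compound 3 is estimated at 55000 nM, with an expected range of 20000 nM to 110000 nM.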

Compound 3, half-maximal inhibitory concentration: 65000 nM
Beside the measured number, compound 3's estimate is 1.2-fold (0.07 log units) below it; low and high end bracket the measured number.
By their numbers in this assay, from the lowest: compounds 1, 3 and 2 (each within the scatter of the next).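

Adding butyl four bonds along the chain from the amine nitrogen gives a 1.1-fold lower number from compound 2 to compound 3 (0.04 log units; within the scatter) in this assay, and the longer hexyl addition gives no change at the digits printed from compound 1 to compound 3 (within the scatter) in the same assay. The ethyl, butyl and octyl chains therefore stay level within the scatter, so the flat result now holds for the longest chain as well as for the first extension. No available evidence bears on this result. From the compounds shown here alone, it remains open whether a branched chain, a chain ending in an amine or a carboxylic acid, or a phenyl ring at this position would separate from these compounds.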